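Chloro addition in a triazole series: extending one step

This account rests on a few compounds, and the source may have more. Where it says the series, first, only, none or still open, it means among the compounds named here.

Compound 1 `Cc1ccccc1-c1n[nH]c(-c2ccccc2)n1` and compound 2 `COc1cccc(-c2n[nH]c(-c3ccccc3C)n2)c1` differ in their cores; the difference between the two cores is not broken down here. In a functional assay on the whole organism (Cricetulus griseus) with Cricetinae gen. sp. as the target (on this read-out higher numbers stand for an effect only at larger amounts of compound and lower numbers for an effect already at smaller amounts), compound 1 gives 10 mg/kg and compound 2 gives 5 mg/kg. Compound 3 `Cc1cc(Cl)ccc1-c1n[nH]c(-c2ccccc2)n1` carries chloro in place of hydrogen on an aromatic carbon relative to compound 1. In this assay compound 3 gives 4 mg/kg; the step of a 2.5-fold lower number from compound 1 to compound 3 (0.40 log units; beyond the scatter). Compound 4 `COc1cccc(-c2n[nH]c(-c3ccc(Cl)cc3C)n2)c1` carries chloro in place of hydrogen on an aromatic carbon relative to compound 2, the same change, at the same place. Within the data shown here, for compound 4 a step of comparable size is expected, a 2.5-fold lower number from compound 2 to compound 4 (0.40 log units; beyond the scatter), because the measured step of a 2.5-fold lower number from compound 1 to compound 3 (0.40 log units; beyond the scatter) is the only case of this change seen so far and rests on a single pair. Compound 4 is therefore estimated at 2 mg/kg in this assay, with a range from 0.8 mg/kg to 5 mg/kg.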

Compound 4, dose for half-maximal effect: 5 mg/kg
For compound 4 the middle estimate is 2.5-fold (0.40 log units) below the measured one; low and high end bracket the measured number.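

In this assay the chloro change gives no change at the digits printed from compound 2 to compound 4 (within the scatter). Set beside the earlier step, the two cores cannot be told apart on this change: the same change on two cores in this assay, a 2.5-fold lower number (0.40 log units; beyond the scatter) from compound 1 to compound 3 and no change at the digits printed (within the scatter) from compound 2 to compound 4, 2.5-fold (0.40 log units) apart, within the scatter of two such steps. Among these compounds, this shows neither that the chloro step carries over from one core to the other nor that it depends on the core, since each core supplies only a single pair and the two pairs together cannot settle the matter.

Still open, going by these compounds, is how the chloro step behaves on any further core. Also open, on these data alone, is what a different group on the same aromatic carbon, such as fluoro, an amine or a carboxylic acid, would do to the read-out.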